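The compounds below may be only part of what the source reports. "The series", "measured", "known", "first", "only" and "open" are said of these compounds alone.

Working notes on the series. Compound 1 `CC1=CC[C@H](C(C)(C)NC(=S)NN)CC1` carries the shared core with an open terminal arm. In a functional assay on K562 cells (Homo sapiens) for inhibition, read by sulforhodamine B assay, with a stated time of 48 h (a lower number here means a stronger inhibitor of growth, a higher number a weaker inhibitor of growth), compound 1 reaches only the limit > 100000 nM, which is a limit rather than a number. Compound 2 `CC1=CC[C@H](C(C)(C)NC(=S)N/N=C(\C)c2ccccc2)CC1` closes that arm onto an aromatic ring. In this assay compound 2 also stands at the limit > 100000 nM, again a limit and not a number. Compound 3 `COc1ccc(/C(C)=N/NC(=S)NC(C)(C)[C@H]2CC=C(C)CC2)cc1` differs from compound 2 by methoxy in place of hydrogen on an aromatic carbon and is the one member with a finite reading: in this assay compound 3 gives 54000 nM, the only number shown, since the other two entries sit at the limit of > 100000 nM in this assay, at which 2 of the 3 values shown sit. The step of an at least 1.8-fold lower number from compound 2 to compound 3 (0.26 log units; that floor lies within the scatter) is thus modest, its floor lying inside the scatter.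

Compound 4 `CC1=CC[C@H](C(C)(C)NC(=S)N/N=C(\C)c2ccc([N+](=O)[O-])cc2)CC1` is not yet measured. It differs from compound 3 by nitro in place of methoxy on an aromatic carbon. Among the compounds with values here, the only measured step that touches that aromatic carbon is the one from hydrogen to methoxy, and it gave no more than a floor within the scatter, so no measured step speaks for a change beyond the scatter here. Compound 4 is expected to give about 45000 nM in this assay, within a range of 12000 nM to 150000 nM. The expected step of a 1.2-fold lower number from compound 3 to compound 4 (0.08 log units; within the scatter) is therefore small, with a real chance that only a limit is reported.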

Compound 4, concentration for 50% growth inhibition: 83400 nM
The estimate for compound 4 lay 1.9-fold (0.27 log units) below the measured number, within the range that was stated.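

Nitro and methoxy can now be set against each other on the same aromatic carbon, para to a large group, and in this assay the exchange gives a 1.5-fold higher number from compound 3 to compound 4 (0.19 log units; within the scatter). Within the data shown here, two different groups at this position thus give finite readings that lie within the scatter of each other, which the single methoxy reading could not show, so this change gives no ranking of the two groups. The second step at this position reads an at least 1.1-fold lower number from compound 2 to compound 4 (0.07 log units; that floor lies within the scatter), and it stays a floor because its starting value is a limit and not a number: the limit of > 100000 nM in this assay, at which 2 of the 4 values shown sit.

The compounds shown leave open whether any group on this aromatic carbon can move the reading beyond the scatter, since both steps from hydrogen are floors within the scatter and the step between methoxy and nitro also lies within it. An amine, a carboxylic acid or a longer chain in place of nitro or methoxy at this position would show whether the insensitivity seen so far extends beyond these two groups.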